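Halogen swap on the benzyl arm of compound 1

The source may hold more compounds than are shown below. What is called first, only, known or untested is meant among the compounds shown, and "the series" means these compounds.

Compound 1 `COc1cc(-c2nnc(SCc3ccccc3F)o2)ccc1O` and compound 2 `COc1cc(-c2nnc(SCc3ccc(F)cc3F)o2)ccc1O` share one core and differ only on the aromatic ring of the benzyl arm. In a functional assay on cells (T-cell, Mus musculus, strain BALB/c) for inhibition, read by MTT assay, with stated times of 24 h and 72 h (a lower number here means a stronger inhibitor, a higher number a weaker inhibitor), compound 1 gives 5790 nM and compound 2 gives 9690 nM. On the two numbers available, compound 1 stands at the smaller one, yet a 1.7-fold higher number from compound 1 to compound 2 (0.22 log units; within the scatter) is within the scatter, so the two compounds cannot be ranked by this assay.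

Compound 3 `COc1cc(-c2nnc(SCc3cccc(Cl)c3)o2)ccc1O` is not yet measured. Its change from compound 1 is 3-chlorophenyl in place of 2-fluorophenyl on a saturated chain carbon bound to a sulfur. Within the data shown here, the only measured step that bears on it is a 1.7-fold higher number from compound 1 to compound 2 (0.22 log units; within the scatter), a fluoro added to the same aromatic ring, and that step stayed inside the scatter. Among the measured compounds shown here, no measured pair shows a chloro on this ring, and none shows a halogen moved from one place to another, so the evidence for compound 3 is thin. For the measured compounds named here, on the one step available, the expected step is a 1.0-fold higher number from compound 1 to compound 3 (0.02 log units; within the scatter), that is, no movement beyond the scatter. For compound 3 the estimated value in this assay is 6000 nM, with a range from 2500 nM to 15000 nM.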

Compound 3, half-maximal inhibitory concentration: 8290 nM
Beside the measured number, compound 3's estimate is 1.4-fold (0.14 log units) below it; low and high end bracket the measured number.
By their numbers in this assay, from the lowest: compounds 1, 3 and 2 (each within the scatter of the next).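

Replacing 2-fluorophenyl with 3-chlorophenyl on a saturated chain carbon bound to a sulfur alters both the halogen and where it sits on the ring, a kind of change the fluoro addition in the earlier pair did not test, yet in this assay the step is small (a 1.4-fold higher number from compound 1 to compound 3 (0.16 log units; within the scatter)). The comparison with the difluorinated arm is equally flat (a 1.2-fold lower number from compound 2 to compound 3 (0.07 log units; within the scatter)), so 2-fluorophenyl, 2,4-difluorophenyl and 3-chlorophenyl cannot be separated at this position by this read-out, and all three steps among the compounds remain within the scatter. No supporting measurement is available to explain this flat result.

Because the halogen and its place change together here, the compounds shown do not separate the two, and 3-fluorophenyl or 2-chlorophenyl would be needed to read each alone. Also open, on these data alone, is whether this position responds at all to something further from these halogenated arms, such as an unsubstituted phenyl, an amine or a carboxylic acid on the ring, or a longer chain between the sulfur and the ring.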